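This account rests on a few compounds, and the source may have more. Where it says the series, first, only, none or still open, it means among the compounds named here.

Compound 1 `CC(C)Oc1cc(C(=O)O)cc2sc(O[C@@H]3CO[C@H]4[C@@H]3OC[C@H]4OCc3c(-c4ccccc4OC(F)(F)F)noc3C3CC3)nc12`: < 30 nM. Compound 2 `CC(C)Oc1cc(C(=O)O)cc2sc(O[C@@H]3CO[C@H]4[C@H]3OC[C@H]4OCc3c(-c4c(Cl)cccc4Cl)noc3C3CC3)nc12`: < 30 nM.

In an assay on isolated protein for agonist activity at Bile acid receptor (Homo sapiens) (on this read-out higher numbers stand for an effect only at larger amounts of compound and lower numbers for an effect already at smaller amounts), compound 2 gives < 30 nM, which is a limit of the assay rather than a number. Compound 1 likewise gives < 30 nM, again only a limit. Compound 2 thus stands at the limit of < 30 nM in this assay, at which 2 of the 2 values shown sit, and nothing in these numbers separates it from compound 1. Compound 3 `CC(C)Oc1cc(C(=O)NS(=O)(=O)N2CCCC2)cc2sc(O[C@@H]3CO[C@H]4[C@H]3OC[C@H]4OCc3c(-c4c(Cl)cccc4Cl)noc3C3CC3)nc12` differs from compound 2 by ((pyrrolidin-1-yl)sulfonyl)amino in place of hydroxy on a carbonyl carbon. Within the data shown here, no measured step of this kind is available, so the expected step is a step that the limit leaves unreadable from compound 2 to compound 3, none beyond the scatter. Compound 3 is therefore expected to give 20 nM, between 3 nM and 100 nM, quite possibly reported again only as a limit.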

Compound 3, half-maximal effective concentration: < 30 nM
Compound 3: no number, only a limit; the forecaster's own chance of this, stated with the estimate: 60%; the middle value does not contradict the limit.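

No step can be read from compound 2 to compound 3, because both values are only limits: the limit of < 30 nM in this assay, at which 3 of the 3 values shown sit.

The compounds shown leave open whether exchanging carboxy for ((pyrrolidin-1-yl)sulfonyl)carbamoyl changes the amount of compound needed for an effect, and by how much.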